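The compounds below may be only part of what the source reports. "The series", "measured", "known", "first", "only" and "open" are said of these compounds alone.

Compound 1, `CC(=O)Nc1ccc(C2=NNC(=O)CC2)cc1`, is the starting point of this comparison. In a functional assay for inhibition, with Homo sapiens as the target (on this read-out higher numbers stand for an effect only at larger amounts of compound and lower numbers for an effect already at smaller amounts), compound 1 gives 1 ug/mL, the lower of the two numbers that were obtained. Compound 2, `CCCCC(=O)Nc1ccc(C2=NNC(=O)CC2)cc1`, differs from it in one place, propyl in place of hydrogen on a saturated chain carbon bound to a carbonyl carbon, and in this assay compound 2 gives 2.64 ug/mL. That is the step of a 2.6-fold higher number from compound 1 to compound 2 (0.42 log units; beyond the scatter). For compound 3, `CC(=O)Nc1cccc(C2=NNC(=O)CC2)c1`, the measurement in this assay returned no number but only a limit, > 46.4 ug/mL. That limit is the limit of > 46.4 ug/mL in this assay, at which 1 of the 3 values shown sits.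

Compound 4, `CCN(CC)CC(=O)Nc1ccc(C2=NNC(=O)CC2)cc1`, has not yet been measured. It differs from compound 1 by diethylamino in place of hydrogen on a saturated chain carbon bound to a carbonyl carbon. For the measured compounds named here, the only measured step at the same place is a 2.6-fold higher number from compound 1 to compound 2 (0.42 log units; beyond the scatter), a modest rise beyond the scatter when a small chain was added there. Another group entering at the same place is therefore expected to leave the number about where it is or to raise it modestly, rather than to lower it. Compound 4 is thus estimated to give 1.8 ug/mL, with a range from 0.7 ug/mL to 5 ug/mL. The step that this expectation means is a 1.8-fold higher number from compound 1 to compound 4 (0.26 log units; within the scatter), and the measurement will show how close it comes.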

Compound 4, half-maximal effective concentration: about 10 ug/mL
Estimate against measurement, compound 4: 5.6-fold (0.74 log units) below, and the stated range ends below it.
By their numbers in this assay, from the lowest: compound 1; then compound 2; then compound 4. At a limit, above all of these: compound 3.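

In this assay, this place on a saturated chain carbon bound to a carbonyl carbon now carries three different groups, and a 10-fold higher number from compound 1 to compound 4 (1.00 log units; beyond the scatter) shows that a group containing an amine can raise the number further than the step to propyl suggested. The identity of the entering group matters, not merely the fact that something replaces hydrogen, as a 3.8-fold higher number from compound 2 to compound 4 (0.58 log units; beyond the scatter) shows that diethylamino and propyl do not give the same result at this place. Among compound 1, compound 2 and compound 4, hydrogen gives the lowest number and no compound goes against that order, but the measurements shown give no direct explanation of why diethylamino raises the number more than propyl does.

As far as these compounds go, it remains open whether the rise follows the nitrogen of the diethylamino group or simply the larger number of heavy atoms entering at this place. A pentyl chain, a smaller dimethylamino group or a carboxylic acid at the same place could help separate these readings, and a hydroxyl group would show whether the trend extends beyond carbon chains and amines.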